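Hydroxycarbamoyl phenyl to cyclohexyl swap on two cores

A few compounds are considered here, and "the series" means these few. Any claim that something is new, unique, unknown or untested is made for them only; others in the source may bear on it.

Compound 1 `COc1cc2c(NCc3ccc(C(=O)NO)cc3)cc(-c3ccc(C)o3)nc2cc1OCCCN1CCCC1` carries 4-(hydroxycarbamoyl)phenyl on a saturated chain carbon bound to a nitrogen on an aromatic ring, and in an assay on isolated protein for inhibition of protein deacetylase HDAC6 (Homo sapiens), read by fluorescence, with a stated time of 30 min (a lower number here means a stronger inhibitor, a higher number a weaker inhibitor), compound 1 gives 11 nM. Compound 2 `COc1cc2c(NCC3CCC(C(=O)NO)CC3)cc(-c3ccc(C)o3)nc2cc1OCCCN1CCCC1` differs from it by 4-(hydroxycarbamoyl)cyclohexyl in place of 4-(hydroxycarbamoyl)phenyl on a saturated chain carbon bound to a nitrogen on an aromatic ring. In this assay, within the data shown here, compound 2 gives 34 nM, which is the step of a 3.1-fold higher number from compound 1 to compound 2 (0.49 log units; beyond the scatter), the first occurrence of this change in the set.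

Compound 3 `COc1cc2nc(-c3ccc(C)o3)cc(NCc3ccc(C(=O)NO)cc3)c2cc1OC` has a different core: it differs from compound 1 by hydrogen in place of 2-(pyrrolidin-1-yl)ethyl on a saturated chain carbon bound to an oxygen on an aromatic ring. In this assay compound 3 gives 22 nM, a step of a 2.0-fold higher number from compound 1 to compound 3 (0.30 log units; within the scatter), so the two cores do not separate in this read-out.

Compound 4 `COc1cc2nc(-c3ccc(C)o3)cc(NCC3CCC(C(=O)NO)CC3)c2cc1OC` has not yet been measured. It differs from compound 3 by 4-(hydroxycarbamoyl)cyclohexyl in place of 4-(hydroxycarbamoyl)phenyl on a saturated chain carbon bound to a nitrogen on an aromatic ring. This is the same change as from compound 1 to compound 2, with the same surroundings at the place of change, and it occurs two times among the compounds shown. Among the measured compounds shown here, for compound 4 a step of a 3.1-fold higher number from compound 3 to compound 4 (0.49 log units; beyond the scatter) in this assay is expected, beside the earlier 3.1-fold higher number from compound 1 to compound 2 (0.49 log units; beyond the scatter), because the only direct guide is the step of a 3.1-fold higher number from compound 1 to compound 2 (0.49 log units; beyond the scatter) on the other core and the core swap itself stays within the scatter as a 2.0-fold higher number from compound 1 to compound 3 (0.30 log units; within the scatter). A single prior example gives limited confidence in the exact size. Compound 4 is therefore estimated at 68 nM, with a range from 35 nM to 140 nM.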

Compound 4, half-maximal inhibitory concentration: 41 nM
Compound 4: middle estimate off by 1.7-fold (0.22 log units), on the high side; the measured number falls inside the stated range.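

In this assay, 4-(hydroxycarbamoyl)cyclohexyl in place of 4-(hydroxycarbamoyl)phenyl on the core of compound 3 gives a 1.9-fold higher number from compound 3 to compound 4 (0.27 log units; within the scatter), and hydrogen in place of 2-(pyrrolidin-1-yl)ethyl with the cyclohexyl group present gives a 1.2-fold higher number from compound 2 to compound 4 (0.08 log units; within the scatter), so neither new step separates its pair. The ring change carries from one core to the other with no difference in size that can be told apart, even though only the earlier of its two steps lies beyond the scatter: the same change on two cores in this assay, a 3.1-fold higher number (0.49 log units; beyond the scatter) from compound 1 to compound 2 and a 1.9-fold higher number (0.27 log units; within the scatter) from compound 3 to compound 4, 1.7-fold (0.22 log units) apart, within the scatter of two such steps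

The change at the ether chain behaves the same way on both ring groups, but two readings of each change show only this one pairing and neither fix the size of a step nor show that it would hold on any further core: the same change on two cores in this assay, a 2.0-fold higher number (0.30 log units; within the scatter) from compound 1 to compound 3 and a 1.2-fold higher number (0.08 log units; within the scatter) from compound 2 to compound 4, 1.7-fold (0.22 log units) apart, within the scatter of two such steps

From the compounds shown here alone, it remains open whether the ring change keeps this size when the pyrrolidine of the 2-(pyrrolidin-1-yl)ethyl group is replaced by a morpholine or a dimethylamine. Going by these compounds, it is also open how a piperidine ring carrying the hydroxycarbamoyl group, in place of the phenyl or cyclohexyl ring, would read in this assay.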